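Aryl swap: compound 3 to compound 4

A few compounds are considered here, and "the series" means these few. Any claim that something is new, unique, unknown or untested is made for them only; others in the source may bear on it.

- compound 1 `C=C(C)c1ccc(N2CCN(C(=O)c3oc(C)nc3-c3ccccc3)CC2)cc1` gives "not active" (no number reported)
- compound 2 `Cc1nc(-c2ccccc2)c(C(=O)N2CCN(c3ccccc3Cl)CC2)o1` gives 124 nM
- compound 3 `Cc1nc(-c2ccccc2)c(C(=O)N2CCN(c3c(C)cccc3C)CC2)o1` gives 146 nM

In a functional assay on HL-60 cells (Homo sapiens) for inhibition, read by MTT assay, with a stated time of 72 h (a higher number here means a weaker inhibitor, a lower number a stronger inhibitor), compound 3 stands at 146 nM, level within the scatter with compound 2 at 124 nM. Compound 4 `COc1cc(OC)cc(N2CCN(C(=O)c3oc(C)nc3-c3ccccc3)CC2)c1` follows from 3,5-dimethoxyphenyl in place of 2,6-dimethylphenyl on an amine nitrogen in a ring, with 3,5-dimethoxyphenyl in place of 2,6-dimethylphenyl on an amine nitrogen in a ring.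

Within the data shown here, the only measured step at this place is a 1.2-fold higher number from compound 2 to compound 3 (0.07 log units; within the scatter), which stays within the scatter. Against that, compound 1 is "not active" (no number reported), so a different aryl group here can cost all measurable activity. A somewhat higher number is therefore expected, as the step of a 1.5-fold higher number from compound 3 to compound 4 (0.18 log units; within the scatter).

For compound 4 the estimated value is 220 nM, with an expected range of 50 nM to 1500 nM.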

Compound 4, half-maximal inhibitory concentration: 19.2 nM
Compound 4: the middle estimate sits 11-fold (1.06 log units) above what was measured; measured number below the stated range.
By their numbers in this assay, from the lowest: compound 4; then compounds 2 and 3 (each within the scatter of the next).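

In this assay the aryl group on the ring nitrogen can shift the number beyond the scatter: 3,5-dimethoxyphenyl gives a 7.6-fold lower number from compound 3 to compound 4 (0.88 log units; beyond the scatter) and a 6.5-fold lower number from compound 2 to compound 4 (0.81 log units; beyond the scatter) in the same series. The earlier measured aryl swap stayed within the scatter, so this position tolerates more than a loss of activity or no change. The entering group brings hydrogen-bond acceptors that 2,6-dimethylphenyl lacks, but nothing available explains the gain. Open, from the compounds shown here alone, is whether the gain follows the methoxy groups or the 3,5-substitution; 3,5-dimethylphenyl or 3-methoxyphenyl would separate these.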